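The source may report more compounds than this note shows. Statements on the series, on what has been measured and on what is new or still open speak of the compounds shown alone.

Compound 1 `CCCC1C(=O)N(O)C(=O)c2ccccc21`: 25400 nM
Compound 2 `O=C1c2ccccc2C(CCc2ccccc2)C(=O)N1O`: 30000 nM

For the measured compounds named here, in an ADME assay on MT4 cells (Homo sapiens) for cytotoxicity, read by MTT assay (on this read-out higher numbers stand for lower toxicity in this test and lower numbers for higher toxicity in this test), compound 2 gives 30000 nM and stands level with compound 1, the only other compound measured so far, so neither can be ranked over the other. The next compound is compound 3 `CCCCCC1C(=O)N(O)C(=O)c2ccccc21`, which keeps the shared core and differs from compound 2 in the chain: propyl in place of phenyl on a saturated chain carbon, two bonds along the chain from a saturated ring carbon. In words, this is propyl in place of phenyl on a saturated chain carbon, two bonds along the chain from a saturated ring carbon. Going by the values given here, one measured step bears on this change, at the same place: a 1.2-fold higher number from compound 1 to compound 2 (0.07 log units; within the scatter). That step puts phenyl in place of methyl and stays within the scatter. A swap of propyl for phenyl is therefore not expected to give a step beyond the scatter in this assay. Among the compounds with values here, this expectation rests on a single step, and no propyl compound has been measured yet. The expected change is a 1.3-fold lower number from compound 2 to compound 3 (0.12 log units; within the scatter). Compound 3 is estimated at 23000 nM, with an expected range from 10000 nM to 50000 nM.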

Compound 3, half-maximal cytotoxic concentration: 98300 nM
Beside the measured number, compound 3's estimate is 4.3-fold (0.63 log units) below it; the measured number lies above the stated range.
By their numbers in this assay, from the lowest: compounds 1 and 2 (each within the scatter of the next); then compound 3.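

In this assay the far end of this chain now matters: there is a 3.3-fold higher number from compound 2 to compound 3 (0.52 log units; beyond the scatter) with propyl in place of phenyl, a step beyond the scatter that the earlier pair gave no sign of, since phenyl in place of methyl stayed within it. The all-carbon chain can also shift the number without any ring being removed, as there is a 3.9-fold higher number from compound 1 to compound 3 (0.59 log units; beyond the scatter) with ethyl in place of hydrogen on a saturated chain carbon, three bonds along the chain from a saturated ring carbon. No evidence is available to explain why compound 3 stands apart from compound 1 and compound 2.

The groups shown at this place are made of carbon only, so it remains open whether an amine or a carboxylic acid on the chain would track with the propyl or the phenyl compound. Going by these compounds, it is also open whether a longer chain than that of compound 3 would raise the number further or whether the rise stops there.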